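Working notes on the step from compound 2

A few compounds are considered here, and "the series" means these few. Any claim that something is new, unique, unknown or untested is made for them only; others in the source may bear on it.

- compound 1 `CN(/N=N/c1ccc(C#N)cc1)C(=O)CCc1ccc(O)cc1` gives 5.8 h in an ADME assay on a cell-free system (plasma, Homo sapiens) for metabolic stability, read by HPLC (on this read-out higher numbers stand for a longer-lived compound and lower numbers for a shorter-lived compound), as measured
- compound 2 `COC(=O)c1ccc(/N=N/N(C)C(=O)CCCCc2ccc(O)cc2)cc1` gives 17.5 h in this assay as measured

Compound 2 stands highest of these two numbers, and its gap to compound 1 lies beyond the usual scatter. The step to compound 3 `COC(=O)c1ccc(/N=N/N(C)C(=O)CCc2ccc(O)cc2)cc1` is 4-hydroxyphenyl in place of 2-(4-hydroxyphenyl)ethyl on a saturated chain carbon, two bonds along the chain from a carbonyl carbon and sits on a saturated chain carbon, two bonds along the chain from a carbonyl carbon. Among the measured compounds shown here, no measured step shows what this change does in this assay so the only guide is compound 1 at 5.8 h and a drop just beyond the scatter is expected. The estimated change is a 2.2-fold lower number from compound 2 to compound 3 (0.34 log units; beyond the scatter) as a working figure. For compound 3 the expected half-life is 8 h with an estimated range from 3.5 h to 18 h for now.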

Compound 3, half-life: 7.3 h
Compound 3: middle estimate off by 1.1-fold (0.04 log units), on the high side; low and high end bracket the measured number.
By their numbers in this assay, from the lowest: compounds 1 and 3 (each within the scatter of the next); then compound 2.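

In this assay, among the compounds shown here, 4-hydroxyphenyl in place of 2-(4-hydroxyphenyl)ethyl on a saturated chain carbon, two bonds along the chain from a carbonyl carbon, gives a 2.4-fold lower number from compound 2 to compound 3 (0.38 log units; beyond the scatter) as the first direct reading at this position. Methoxycarbonyl in place of cyano on an aromatic carbon gives a 1.3-fold higher number from compound 1 to compound 3 (0.10 log units; within the scatter) and so shows no separable change in half-life. No evidence at hand accounts for either step. Going by these compounds, it remains open whether a longer chain than in compound 2 gives a still higher number at the saturated carbon. On these data alone, how a carboxylic acid in place of methoxycarbonyl on the aromatic carbon reads also remains open.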